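The source may report more compounds than this note shows. Statements on the series, on what has been measured and on what is new or still open speak of the compounds shown alone.

Measured in an ADME assay on L02 cells (Homo sapiens) for cytotoxicity, read by MTT assay, with a stated time of 24 h; on this read-out lower numbers stand for stronger inhibition and higher numbers for weaker inhibition:
- Compound 1 `CN1C/C(=C\c2cccc([N+](=O)[O-])c2)C(=O)/C(=C/c2ccc(Cl)cc2Cl)C1`: 14000 nM
- Compound 2 `CN1C/C(=C\c2ccc(Br)cc2)C(=O)/C(=C/c2ccc(C#N)cc2)C1`: 10500 nM

In this assay, compound 2 at 10500 nM stands within the scatter of compound 1 at 14000 nM, so the two values cannot be told apart. Going by the values given here, these two compounds differ in more than one place, and no measured pair yet isolates a single change.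

The next compound to be tested is compound 3 `CN1C/C(=C\c2ccc(C#N)cc2)C(=O)/C(=C/c2ccc(Cl)cc2Cl)C1`. It departs from compound 2 by one exchange, 2,4-dichlorophenyl in place of 4-bromophenyl on a double-bonded chain carbon bound to a double-bonded ring carbon. The entering 2,4-dichlorophenyl is also present in compound 1, whose value of 14000 nM lies close to that of compound 2. On that slim evidence, no step beyond the scatter is expected in this assay, and no direction can be favoured. The expected change is a 1.1-fold higher number from compound 2 to compound 3 (0.04 log units; within the scatter). For compound 3 the estimated value is 11500 nM, with an expected range of 5000 nM to 26000 nM.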

Compound 3, half-maximal inhibitory concentration: 10800 nM
Estimate against measurement, compound 3: 1.1-fold (0.03 log units) above; the range from low to high includes it.
By their numbers in this assay, from the lowest: compounds 2, 3 and 1 (each within the scatter of the next).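

In this assay the exchange of 4-bromophenyl for 2,4-dichlorophenyl on a double-bonded chain carbon bound to a double-bonded ring carbon gives a 1.0-fold higher number from compound 2 to compound 3 (0.01 log units; within the scatter) and thus offers the first single-place reading: at this place, with 4-cyanophenyl retained, the two halogen-bearing phenyl groups cannot be told apart, despite the difference in their heavy atoms. The second pair, with 2,4-dichlorophenyl retained, places 4-cyanophenyl instead of 3-nitrophenyl on a double-bonded chain carbon bound to a double-bonded ring carbon and gives a 1.3-fold lower number from compound 1 to compound 3 (0.11 log units; within the scatter) and so shows that this exchange, too, leaves the read-out within the scatter. Nothing available explains why either exchange leaves the number where it stands.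

Going by these compounds alone, every group compared so far at these places is a substituted phenyl ring, and no step among the three compounds lies beyond the scatter, so what would move the number in this assay remains unknown. From the compounds shown here alone, whether an amine, a carboxylic acid or a longer chain on such a phenyl ring would give a step beyond the scatter also remains open.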